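One nitrile out, two methyls in: expecting compound 4

A few compounds are considered here, and "the series" means these few. Any claim that something is new, unique, unknown or untested is made for them only; others in the source may bear on it.

Three compounds built on one shared core were measured in an assay on cells for agonist activity at ecdysone receptor (Bombyx mori), read by a luciferase reporter, with a stated time of 24 h; on this read-out higher numbers stand for an effect only at larger amounts of compound and lower numbers for an effect already at smaller amounts. Compound 1 `CC(C)(C)N(NC(=O)c1ccccc1)C(=O)c1ccccc1F` gives 309 nM; compound 2 `CCc1ccccc1C(=O)N(NC(=O)c1ccccc1)C(C)(C)C` gives 589 nM; compound 3 `CC(C)(C)N(NC(=O)c1cccc(C#N)c1)C(=O)c1ccccc1Cl` gives 955 nM, the highest of the three numbers, within the scatter of compound 2 but beyond it against compound 1. Among the compounds with values here, the only step between measured compounds, a 1.9-fold higher number from compound 1 to compound 2 (0.28 log units; within the scatter), alters a different part of the molecule. Compound 4 `Cc1ccc(C(=O)NN(C(=O)c2ccccc2Cl)C(C)(C)C)cc1C` differs from compound 3 in one place: 3,4-dimethylphenyl in place of 3-cyanophenyl on a carbonyl carbon. Within the data shown here, no measured step bears on this change, so the expectation rests on compound 3 alone and is loosely held. Compound 4 is expected to give 300 nM, with a range from 80 nM to 1200 nM. The expected step is a 3.2-fold lower number from compound 3 to compound 4 (0.50 log units; beyond the scatter).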

Compound 4, half-maximal effective concentration: 87.1 nM
The estimate for compound 4 lay 3.4-fold (0.54 log units) above the measured number; the measured number falls inside the stated range.
By their numbers in this assay, from the lowest: compound 4; then compounds 1, 2 and 3 (each within the scatter of the next, the first and the last beyond it).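

Within the data shown here, at the place on a carbonyl carbon whose other neighbour is the amide-type nitrogen, the group matters a great deal: in this assay, 3,4-dimethylphenyl in place of 3-cyanophenyl gives an 11-fold lower number from compound 3 to compound 4 (1.04 log units; beyond the scatter) and so brings a large change that no earlier step could show. Both groups have the same heavy-atom count, but the nitrile and its hydrogen-bond acceptor are gone. Nothing measured here explains the step. The nitrile's loss and the two methyls' arrival cannot be told apart. On these data alone, how a methoxy group or an amine on this ring would read also remains open.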